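A few compounds are considered here, and "the series" means these few. Any claim that something is new, unique, unknown or untested is made for them only; others in the source may bear on it.

Measured so far:
- compound 1, `Nc1nc(-c2cccc(NC(=O)c3ccc[nH]3)c2)cn1C(=O)c1ccc[nH]1`; in an assay on isolated protein for inhibition of sodium channel protein type 4 subunit alpha (Homo sapiens), read by electrophysiology, with a stated time of 4 min (on this read-out higher numbers stand for weaker inhibition and lower numbers for stronger inhibition), compound 1 gives > 30000 nM
- compound 2, `CC(C)(C)OC(=O)n1cc(-c2cccc(NC(=O)c3cc4ccccc4[nH]3)c2)nc1N`; compound 2 gives > 30000 nM
- compound 3, `CNc1nc(-c2cccc(NC(=O)c3ccco3)c2)cn1C(=O)OC(C)(C)C`; compound 3 gives > 30000 nM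

The result for compound 1 is a limit of the assay, not a number. The result for compound 2 is likewise a limit. The result for compound 3 is also a limit, so compound 3 stands nowhere on a scale of numbers: it simply sits at the limit of > 30000 nM in this assay, at which 3 of the 3 values shown sit. No pair of these compounds differs in one place, so no measured step can be drawn between them.

Compound 4, `CNc1nc(-c2cccc(NC(=O)c3cc4ccccc4[nH]3)c2)cn1C(=O)OC(C)(C)C`, differs from compound 3 by 1H-indol-2-yl in place of furan-2-yl on a carbonyl carbon. Compound 2 already carries this same indole amide, and in this assay compound 2 gives > 30000 nM. That result for compound 2 is a limit as well. On this basis no movement beyond the scatter is expected, and the step from compound 3 to compound 4 is estimated as a step that the limit leaves unreadable from compound 3 to compound 4. Compound 4 is therefore expected to give about 40000 nM, within a range from 15000 nM to 100000 nM, most likely reported again only as a limit.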

Compound 4, half-maximal inhibitory concentration: > 30000 nM
Compound 4: no number, only a limit; the forecaster's own chance of this, stated with the estimate: 85%; the middle value is on the limit's open side.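

Neither the step from compound 3 to compound 4 nor the step from compound 2 to compound 4 can be read, because both ends of each step are limits: the limit of > 30000 nM in this assay, at which 4 of the 4 values shown sit. The compounds shown leave open whether any change to them would give a number in this assay rather than a limit.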